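Naphthylamides with a hexafluorocarbinol: moving the chlorine

A few compounds are considered here, and "the series" means these few. Any claim that something is new, unique, unknown or untested is made for them only; others in the source may bear on it.

Measured so far in an assay on LtK cells with ATP-sensitive inward rectifier potassium channel 11 (Homo sapiens) as the target; on this read-out higher numbers stand for an effect only at larger amounts of compound and lower numbers for an effect already at smaller amounts:
compound 1 `CC(C)=CC(=O)Nc1c(C(O)(C(F)(F)F)C(F)(F)F)ccc2ccccc12` gives 46 nM
compound 2 `COCC(=O)Nc1c(C(O)(C(F)(F)F)C(F)(F)F)ccc2ccccc12` gives 213 nM
compound 3 `O=C(Nc1c(C(O)(C(F)(F)F)C(F)(F)F)ccc2ccccc12)c1ccccc1Cl` gives 2040 nM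

The three share a core and differ only in the group on the carbonyl carbon of the amide. Compound 3 stands highest of the three numbers in this assay: a 44-fold higher number from compound 1 to compound 3 (1.65 log units; beyond the scatter) and a 9.6-fold higher number from compound 2 to compound 3 (0.98 log units; beyond the scatter). Both steps run in the same direction and lie beyond the scatter, so the 2-chlorophenyl amide is the weakest of the three.

Compound 4 `O=C(Nc1c(C(O)(C(F)(F)F)C(F)(F)F)ccc2ccccc12)c1ccc(Cl)cc1` keeps the same atoms, joined differently: 4-chlorophenyl in place of 2-chlorophenyl on a carbonyl carbon. For the measured compounds named here, no measured step exchanges one chlorophenyl for another, so the pair compounds 3 and 4 has no direct precedent here; the measured steps only show how far compound 3 sits from the other two. A number not far from that of compound 3 is expected, direction open, and the step of a 1.7-fold lower number from compound 3 to compound 4 (0.23 log units; within the scatter) is the estimate. For compound 4 the expected value in this assay is 1200 nM, with a range from 250 nM to 6000 nM.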

Compound 4, half-maximal effective concentration: 570 nM
For compound 4 the middle estimate is 2.1-fold (0.32 log units) above the measured one; low and high end bracket the measured number.
By their numbers in this assay, from the lowest: compound 1; then compound 2; then compound 4; then compound 3.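

In this assay the place of the chlorine counts at this position: the same atoms, joined differently, give a clear step (a 3.6-fold lower number from compound 3 to compound 4 (0.55 log units; beyond the scatter)), so compound 3 does not speak for chlorophenyl amides as a whole. Compound 4 still stays on the weaker side of the methoxymethyl amide (a 2.7-fold higher number from compound 2 to compound 4 (0.43 log units; beyond the scatter)) and of the 2-methylprop-1-en-1-yl amide (a 12-fold higher number from compound 1 to compound 4 (1.09 log units; beyond the scatter)), so both chlorophenyl amides rank behind compound 1 and compound 2, the 4-chlorophenyl amide by a smaller margin. Nothing available here bears on why the place of the chlorine matters.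

Where a 3-chlorophenyl amide would fall relative to compound 3 and compound 4 remains open. So does whether the unsubstituted phenyl amide, or a 4-fluorophenyl or 4-methoxyphenyl amide, would follow compound 4.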